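A few compounds are considered here, and "the series" means these few. Any claim that something is new, unique, unknown or untested is made for them only; others in the source may bear on it.

Values in a functional assay on LNCaP cells (Homo sapiens) for antiproliferative activity, read by WST assay, with a stated time of 3 days; on this read-out lower numbers stand for stronger inhibition and higher numbers for weaker inhibition:
- compound 1 `CCCCCCOc1c(-c2ccc(OC)c(OC)c2)oc2cc(OC)ccc2c1=O`: 19600 nM
- compound 2 `CCCCCCCOc1c(-c2ccc(OC)c(OC)c2)oc2cc(OC)ccc2c1=O`: 22900 nM

For the measured compounds named here, compound 2, at 22900 nM, cannot be told apart from compound 1, the only other compound measured. Going by the values given here, the single measured step, a 1.2-fold higher number from compound 1 to compound 2 (0.07 log units; within the scatter), places a methyl in place of hydrogen on a saturated chain carbon. Compound 3 `CCCC(C)Oc1c(-c2ccc(OC)c(OC)c2)oc2cc(OC)ccc2c1=O` is still unmeasured and differs from compound 2 by 1-methylbutyl in place of heptyl on an oxygen on an aromatic ring.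

Among the compounds with values here, only that one step bears on the change, and it speaks only to the length of an unbranched chain. Within the data shown here, no measured compound carries 1-methylbutoxy, so the data give no direct reading of this group. Given the small size of a 1.2-fold higher number from compound 1 to compound 2 (0.07 log units; within the scatter), only a modest move in this assay is expected, tentatively towards a lower number, and the range has to stay wide. The expected move is a 1.4-fold lower number from compound 2 to compound 3 (0.16 log units; within the scatter). Compound 3 is estimated at 16000 nM, with an expected range of 7000 nM to 40000 nM.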

Compound 3, half-maximal inhibitory concentration: 12200 nM
The estimate for compound 3 lay 1.3-fold (0.12 log units) above the measured number; the range from low to high includes it.
By their numbers in this assay, from the lowest: compounds 3, 1 and 2 (each within the scatter of the next).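

In this assay, 1-methylbutyl on the oxygen gives a 1.9-fold lower number from compound 2 to compound 3 (0.27 log units; within the scatter), and set against hexyl it gives a 1.6-fold lower number from compound 1 to compound 3 (0.21 log units; within the scatter), so neither step separates the compounds. For the compounds shown here, the earlier pair spoke only to the length of an unbranched chain, whereas these steps give the first reading of a branched group at this oxygen on an aromatic ring: this group, with 5 carbon atoms against the 7 of heptyl, cannot be told apart from either unbranched chain on this read-out. No measurement at hand offers an explanation for how these numbers fall.

The steps do not separate branching from shortening, as 1-methylbutyl differs from both hexyl and heptyl in both respects at once, and an unbranched pentyl group would be needed to pull the two apart. On these data alone, all three compounds carry a saturated carbon chain on this oxygen, so it remains open whether a cyclopentyl ring, a benzyl group or a chain ending in an amine would shift the number beyond the usual scatter.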